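N-Hydroxyurea alkyne series: side-chain trimming at the propargylic carbon

The compounds below may be only part of what the source reports. "The series", "measured", "known", "first", "only" and "open" are said of these compounds alone.

Measured so far:
compound 1 `CC(C)C(C#Cc1cccc(C(=O)NCc2ccccc2C(F)(F)F)c1)N(O)C(N)=O`: 500 nM
compound 2 `CNc1nc(C)nc(N[C@H]2CCC[C@@H](C(=O)NCc3ccc(C#N)cc3C(F)(F)F)C2)n1`: "not determined" (no result reported)
compound 3 `C[C@H](C#Cc1cccc(C(=O)NCCC(c2ccccc2)c2ccc(Cl)c(Cl)c2)c1)N(O)C(N)=O`: 96 nM

In an assay for inhibition of Polyunsaturated fatty acid 5-lipoxygenase (Homo sapiens), read by HPLC, with stated times of 15 min and 10 min (on this read-out lower numbers stand for stronger inhibition and higher numbers for weaker inhibition), compound 1 gives 500 nM, the higher of the two numbers on hand, and compound 3 gives 96 nM, a number that lies beyond the scatter below it. Compound 2 carries "not determined" (no result reported) in this assay. Compound 4 `CCC(C#Cc1cccc(C(=O)NCc2ccccc2C(F)(F)F)c1)N(O)C(N)=O` differs from compound 1 by hydrogen in place of methyl on a saturated chain carbon bound to two saturated chain carbons, that is, isopropyl to ethyl on the carbon that bears the hydroxyurea. Going by the values given here, no measured pair shows this change, so no step size is known. A small step is expected, toward a weaker read-out at most and likely not beyond the scatter, a 1.3-fold higher number from compound 1 to compound 4 (0.11 log units; within the scatter). Compound 4 is therefore estimated at 650 nM, with a range from 250 nM to 1700 nM.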

Compound 4, half-maximal inhibitory concentration: 500 nM
Estimate against measurement, compound 4: 1.3-fold (0.11 log units) above; the range from low to high includes it.
By their numbers in this assay, from the lowest: compound 3; then compounds 1 and 4 (each within the scatter of the next).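

In this assay, going by these compounds alone, isopropyl to ethyl on the carbon that bears the hydroxyurea gives the first readable step at this position: no change at the digits printed from compound 1 to compound 4 (within the scatter). In this pair, the read-out therefore does not respond to removing this methyl. Nothing on hand gives a reason for this result.

Still open, from the compounds shown here alone, is whether a longer chain such as n-butyl, or a phenyl ring, on this carbon would shift the read-out. Also open, going by these compounds, is whether the same trim behaves alike with a different amide portion.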